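The compounds below may be only part of what the source reports. "The series", "measured", "known", "first", "only" and "open" are said of these compounds alone.

Measured so far in a functional assay on PC-3 cells (Homo sapiens) for cytotoxicity, read by MTT assay, with a stated time of 48 h; on this read-out higher numbers stand for weaker inhibition and lower numbers for stronger inhibition:
- compound 1, `Nc1ccccc1Nc1n[n+]([O-])c2ccccc2[n+]1[O-]`: 16100 nM
- compound 2, `C=CCNc1n[n+]([O-])c2ccccc2[n+]1[O-]`: > 56000 nM

Compound 1 carries an aminophenyl group on the ring nitrogen of the shared core and gives 16100 nM in this assay. Compound 2 carries an allyl group on that nitrogen; its entry is only a limit of this assay, > 56000 nM, so for compound 2 no number is known (the limit of > 56000 nM in this assay, at which 1 of the 2 values shown sits). Among the measured compounds shown here, no two measured compounds differ in a single place, so no measured step is available.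

The next compound, compound 3, is `[O-][n+]1nc(Nc2ccccc2)[n+]([O-])c2ccccc21`. It arises from compound 2 by phenyl in place of allyl on a nitrogen on an aromatic ring. The aryl group on this nitrogen brings compound 3 closer in shape to compound 1 than compound 2 is, and compound 1 has a numeric value where compound 2 has only a limit. The change from compound 2 to compound 3 is therefore expected to move this assay downward, toward stronger inhibition, by about an at least 2.2-fold lower number from compound 2 to compound 3 (0.35 log units; beyond the scatter), with the size uncertain since the starting point is a limit. For compound 3 the expected value in this assay is 25000 nM, with a range from 8000 nM to 80000 nM.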

Compound 3, half-maximal inhibitory concentration: 17000 nM
Compound 3: the middle estimate sits 1.5-fold (0.17 log units) above what was measured; low and high end bracket the measured number.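

In this assay, phenyl in place of allyl on a nitrogen on an aromatic ring gives an at least 3.2-fold lower number from compound 2 to compound 3 (0.51 log units; beyond the scatter), so the series now has a step at this nitrogen that lies beyond the scatter, even though one end of it is not a number. Hydrogen in place of amino on an aromatic carbon gives a 1.1-fold higher number from compound 1 to compound 3 (0.02 log units; within the scatter), so in this pair the amino group leaves the read-out within the scatter, and a numeric value in this range does not depend on that amino group. The size of the step at the nitrogen remains a bound, since compound 2 has only a limit and no number: the limit of > 56000 nM in this assay, at which 1 of the 3 values shown sits.

With only allyl and two aromatic groups on this nitrogen, the compounds shown leave open whether a ring there is what matters, or whether a saturated group such as cyclohexyl or a longer chain such as n-butyl would read the same way. They also leave open whether a methoxy group, a carboxylic acid or a chlorine on an aromatic carbon of the phenyl group would move the number beyond the scatter, as the amino group does not in this pair.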